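The source may hold more compounds than are shown below. What is called first, only, known or untested is meant among the compounds shown, and "the series" means these compounds.

Of the compounds shown here, three have been tested in a functional assay on the whole organism (strain Wistar) with Rattus norvegicus as the target, with a stated time of 15 days, at a dose of 30 mg/kg by the oral route; a higher number here means a stronger effect of the compound at the dose given, a lower number a weaker effect. Compound 1 `Cc1nc(COc2ccc(/C=C3\SC(=O)NC3=O)cc2)cs1` gives 26.4%, compound 2 `O=C1NC(=O)/C(=C/c2ccc(OCc3csc(-c4ccccc4)n3)cc2)S1` gives 40.3%, and compound 3 `O=C1NC(=O)/C(=C/c2ccc(OCCSc3nnc(-c4ccccc4)[nH]3)cc2)S1` gives 26.4%. Among the measured compounds shown here, the single measured step between neighbours is a number 13.9 percentage points higher from compound 1 to compound 2 (beyond the scatter), a modest rise that still lies beyond the scatter. Compound 3 stands level with compound 1 at the digits shown; the two together hold the lowest numbers of the three, while compound 2 gives the higher number, beyond the scatter.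

Compound 4 `O=C1NC(=O)/C(=C/c2ccc(OCCSc3nnc(Cc4ccccc4)[nH]3)cc2)S1` differs from compound 3 in one place: benzyl in place of phenyl on an aromatic carbon. For the measured compounds named here, no measured step bears directly on this exchange; the only step on record put a phenyl in place of a methyl, which is a different change. The data therefore give no ground to expect a shift beyond the scatter. For compound 4 in this assay the estimate is 26.4%, with a range from 14% to 40%. The step of no change at the digits printed from compound 3 to compound 4 (within the scatter) is thus expected to stay within the scatter.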

Compound 4, a percentage reported as activity, at one dose (the size of the read-out at that dose, not a potency): 38.3%
Compound 4: middle estimate off by 11.9 percentage points, on the low side; measured number inside the range.
By their numbers in this assay, from the lowest: compounds 1 and 3 (each within the scatter of the next); then compounds 4 and 2 (each within the scatter of the next).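

In this assay, among the compounds shown here, the aromatic carbon of the five-membered aromatic ring with 3 nitrogen now has a measured step of its own, which the earlier compounds did not provide: with benzyl in place of phenyl, the read-out gives a number 11.9 percentage points higher from compound 3 to compound 4 (beyond the scatter). The exchange is small, since phenyl of 6 heavy atoms gives way to benzyl of 7, and both groups hold one six-membered aromatic ring of carbon only, so even this slight change at the position shows up in the read-out. No evidence is available to explain the rise.

From the compounds shown here alone, whether a longer chain such as phenethyl would carry the number further remains open, as does the outcome with an amine or a carboxylic acid at this position. The read-out comes from one dose, and the step describes a stronger effect at that dose only.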